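The compounds below may be only part of what the source reports. "The series", "measured", "known", "first", "only" and "open" are said of these compounds alone.

Measured compounds:
- compound 1, `O=C(Nc1ccc(-c2noc(-c3cccc(NS(=O)(=O)c4ccc(C(F)(F)F)cc4)c3)n2)c(Cl)c1)c1cccnc1`: > 10000 nM
- compound 2, `COc1cccc(S(=O)(=O)Nc2cccc(-c3nc(-c4ccc(NC(=O)c5cccnc5)cc4Cl)no3)c2)c1`: > 10000 nM
- compound 3, `CC(=O)Nc1ccc(S(=O)(=O)Nc2cccc(-c3nc(-c4ccc(NC(=O)c5cccnc5)cc4Cl)no3)c2)cc1`: 2500 nM

In a functional assay on MDA-MB-231 cells (Homo sapiens) for antiproliferative activity, read by MTT assay, with a stated time of 72 h (on this read-out lower numbers stand for stronger inhibition and higher numbers for weaker inhibition), compound 1 gives only a limit, > 10000 nM. Compound 2 likewise gives only a limit, > 10000 nM. Going by the values given here, compound 3 gives 2500 nM, the only number among the three; the other two values sit at the limit of > 10000 nM in this assay, at which 2 of the 3 values shown sit. The readable steps both run to compound 3: an at least 4.0-fold lower number from compound 1 to compound 3 (0.60 log units; beyond the scatter) and an at least 4.0-fold lower number from compound 2 to compound 3 (0.60 log units; beyond the scatter), whereas a step that the two limits leave unreadable from compound 1 to compound 2. Among the compounds with values here, compound 3 therefore stands as the one member of the series with a measurable value in this assay.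

Compound 4, `CNC(=O)Nc1ccc(S(=O)(=O)Nc2cccc(-c3nc(-c4ccc(NC(=O)c5cccnc5)cc4Cl)no3)c2)cc1`, differs from compound 3 by methylamino in place of methyl on a carbonyl carbon. Within the data shown here, no measured step touches this position; the two readable steps change the aryl group on the sulfonyl sulfur, and compound 4 keeps the 4-substituted phenyl of compound 3 with the amide-type nitrogen in place. On that basis the change is expected to give a 1.3-fold lower number from compound 3 to compound 4 (0.10 log units; within the scatter), a step not beyond the scatter. Compound 4 is accordingly estimated at 2000 nM in this assay, within 500 nM to 8000 nM.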

Compound 4, half-maximal inhibitory concentration: 1300 nM
Beside the measured number, compound 4's estimate is 1.5-fold (0.19 log units) above it, within the range that was stated.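

Methylamino in place of methyl on a carbonyl carbon gives a 1.9-fold lower number from compound 3 to compound 4 (0.28 log units; within the scatter), so in this assay this position accepts the added nitrogen and its hydrogen-bond donor without a step that exceeds the scatter. Going by these compounds alone, the comparisons with the other sulfonyl and aromatic substituents now extend beyond acetamido: 4-((methylcarbamoyl)amino)phenyl in place of 3-methoxyphenyl on a sulfonyl sulfur gives an at least 7.6-fold lower number from compound 2 to compound 4 (0.88 log units; beyond the scatter), and (methylcarbamoyl)amino in place of trifluoromethyl on an aromatic carbon gives an at least 7.6-fold lower number from compound 1 to compound 4 (0.88 log units; beyond the scatter), so compound 3 is no longer the only member with a measurable value. These two steps give only a minimum size because compound 1 and compound 2 each stand at a limit rather than a number: the limit of > 10000 nM in this assay, at which 2 of the 4 values shown sit.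

As far as these compounds go, how much larger the group on this carbonyl carbon can become remains open, as dimethylamino, ethylamino or methoxy in place of methylamino would show. Also open, from the compounds shown here alone, is whether a free amine or a carboxylic acid in place of acetamido on the aromatic carbon would keep a measurable value in this assay.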